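The source may hold more compounds than are shown below. What is called first, only, known or untested is meant among the compounds shown, and "the series" means these compounds.

Measured in a functional assay on PBMC cells (Homo sapiens) for cytotoxicity; on this read-out lower numbers stand for stronger inhibition and higher numbers for weaker inhibition:
Compound 1 `CCOC(=O)c1sc(Nc2nc(N3CCC(O)CC3)cc(N3CCC(N(C)C)CC3)n2)nc1C`: > 25000 nM (a limit)
Compound 2 `CCOC(=O)c1sc(Nc2nc(N3CCC(N(C)C)CC3)cc(N3CCCC(CO)C3)n2)nc1C`: > 25000 nM (a limit)

Compound 2 stands only at a limit, with no number behind it. Neither measured compound gives more than this: the limit of > 25000 nM in this assay, at which 2 of the 2 values shown sit. Compound 3 `CCOC(=O)c1sc(Nc2nc(N3CCC(N(C)C)CC3)cc(N3CCN(C)CC3)n2)nc1C` carries a new group on the aromatic carbon: 4-methylpiperazin-1-yl in place of 3-(hydroxymethyl)piperidin-1-yl on an aromatic carbon. Going by the values given here, the one measured change at this place, a step that the two limits leave unreadable from compound 1 to compound 2, gives no size to carry over. No step beyond the scatter can therefore be expected in either direction, and the read-out is expected to stay near that limit. The expected step is a number no higher from compound 2 to compound 3 (the limit leaves the size open). For compound 3 the estimated value is 25000 nM, with an expected range from 10000 nM to 50000 nM.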

Compound 3, half-maximal inhibitory concentration in the PBMC assay: 15000 nM
Compound 3: the middle estimate sits 1.7-fold (0.22 log units) above what was measured; the range from low to high includes it.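

In the PBMC assay compound 3 gives 15000 nM as the only number shown rather than a limit, so 4-methylpiperazin-1-yl gives the first reading on this aromatic carbon. Compound 1 and compound 2 remain at a limit: the limit of > 25000 nM in the PBMC assay, at which 2 of the 3 values shown sit. In the PBMC assay the change gives an at least 1.6-fold lower number from compound 2 to compound 3 (0.22 log units; that floor lies within the scatter) and an at least 1.6-fold lower number from compound 1 to compound 3 (0.22 log units; that floor lies within the scatter). In a physicochemical assay for solubility, at pH 6.5 (a lower number here means a less soluble compound, a higher number a more soluble compound), it gives no change at the digits printed from compound 2 to compound 3 (within the scatter). In the physicochemical assay compound 2 gives 20 ug/mL and compound 3 gives 20 ug/mL.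

The compounds shown leave open how far the true values of compound 1 and compound 2 lie from that of compound 3. They also leave open how a morpholine or a primary amine would read on this carbon.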